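Trimming One Ethoxy Group on a Shared Core

A few compounds are considered here, and "the series" means these few. Any claim that something is new, unique, unknown or untested is made for them only; others in the source may bear on it.

Of the compounds shown here, two built on the same core have so far been measured in an assay on cell membranes for inhibition of cytochrome P450 1A1 (Homo sapiens), read by fluorescence, using microsomes, with a stated time of 10 min; on this read-out lower numbers stand for stronger inhibition and higher numbers for weaker inhibition. Compound 1 `COc1ccc(/C=C/C(=O)c2ccncc2)cc1OC` gives 380 nM in this assay. Compound 2 `CCOc1cc(/C=C/C(=O)c2ccncc2)cc(OCC)c1OCC` gives 92 nM in this assay, the lower of the two numbers, with compound 1 standing well above it, beyond the usual scatter. Compound 3 `CCOc1cc(/C=C/C(=O)c2ccncc2)cc(OC)c1OCC` has not yet been measured. It differs from compound 2 in one place: hydrogen in place of methyl on a saturated chain carbon bound to an oxygen on an aromatic ring. Among the measured compounds shown here, no pair of measured compounds isolates a change of this kind, so its size is not known from the data at hand. The step from compound 2 to compound 3 is expected to be modest, at most a slight weakening and possibly within the scatter: a 1.4-fold higher number from compound 2 to compound 3 (0.15 log units; within the scatter). Compound 3 is therefore estimated at 130 nM in this assay, with a range from 60 nM to 300 nM.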

Compound 3, half-maximal inhibitory concentration: 65 nM
Estimate against measurement, compound 3: 2.0-fold (0.30 log units) above, within the range that was stated.
By their numbers in this assay, from the lowest: compounds 3 and 2 (each within the scatter of the next); then compound 1.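

In this assay, among the compounds shown here, the change from ethoxy to methoxy gives a 1.4-fold lower number from compound 2 to compound 3 (0.15 log units; within the scatter) and is the first step here that isolates a single change on the shared core. The earlier compounds shown here could not show this, as compound 1 and compound 2 differ in more than one place. At this position, removing a methyl from the chain therefore leaves a difference too small to separate from repeat measurements, so compound 2 and compound 3 cannot be told apart on this read-out, and nothing measured here accounts for that result.

On these data alone, it remains open whether a longer chain such as propoxy, or an amine in the same place, would also stay within the scatter or move the number beyond it. Nor do these compounds show whether the same trimming of the remaining ethoxy groups would give a similarly small step.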